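Sulfonamide series on Vero cells: the N-ethyl variant

The source may hold more compounds than are shown below. What is called first, only, known or untested is meant among the compounds shown, and "the series" means these compounds.

Compound 1 `CN(c1ccc(Cl)cc1)S(=O)(=O)C1CC2OC1C(c1ccc(NC(=O)CCCCCCC(=O)O)cc1)=C2c1ccc(O)cc1` is the reference point of the series. In an ADME assay on Vero cells (Chlorocebus sabaeus) for antiproliferative activity, read by MTT assay, with a stated time of 72 h (on this read-out lower numbers stand for stronger inhibition and higher numbers for weaker inhibition), compound 1 gives > 100000 nM, which is a limit of the assay rather than a number. Compound 2 `CN(c1cccc2ccccc12)S(=O)(=O)C1CC2OC1C(c1ccc(NC(=O)CCCCCCC(=O)O)cc1)=C2c1ccc(O)cc1` carries naphthalen-1-yl in place of 4-chlorophenyl on the sulfonamide nitrogen. In this assay compound 2 gives > 100000 nM, again a limit. Compound 3 `CCN(c1ccc(C)cc1)S(=O)(=O)C1CC2OC1C(c1ccc(NC(=O)CCCCCCC(=O)O)cc1)=C2c1ccc(O)cc1` has ethyl(4-methylphenyl)amino in place of (4-chlorophenyl)(methyl)amino on the sulfonyl sulfur. In this assay compound 3 gives > 100000 nM, also a limit. The steps a step that the two limits leave unreadable from compound 1 to compound 2, a step that the two limits leave unreadable from compound 1 to compound 3 and a step that the two limits leave unreadable from compound 2 to compound 3 therefore cannot be read for size, since (the limit of > 100000 nM in this assay, at which 3 of the 3 values shown sit).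

Compound 4 `CCN(c1ccc(Cl)cc1)S(=O)(=O)C1CC2OC1C(c1ccc(NC(=O)CCCCCCC(=O)O)cc1)=C2c1ccc(O)cc1` differs from compound 1 by methyl in place of hydrogen on a saturated chain carbon bound to a sulfonamide nitrogen. The change touches the substituent on the sulfonamide nitrogen, the same region altered in the steps above, and none of those steps yielded a readable size. Nothing in the measured steps points to a shift in this assay beyond the scatter in either direction, and compound 3, which bears an ethyl on its sulfonamide nitrogen, gives > 100000 nM. The step that the limit leaves unreadable from compound 1 to compound 4 is therefore expected to remain unreadable. Compound 4 is estimated at 150000 nM, with a range from 60000 nM to 400000 nM, and is most likely to be reported again only as a limit.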

Compound 4, half-maximal inhibitory concentration: > 100000 nM
Compound 4 ended at the assay's limit (the forecaster's own chance of this, stated with the estimate: 85%); the middle value does not contradict the limit.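

The steps linking compound 4 with compound 1, compound 2 and compound 3 cannot be read for size, because all four compounds sit at the same limit: the limit of > 100000 nM in this assay, at which 4 of the 4 values shown sit.

The compounds shown leave open whether any substituent on the sulfonamide nitrogen gives a measurable value in this assay, and how large a step between them would be.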